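Cytotoxicity limits on a quinoline-free view of three analogues

A few compounds are considered here, and "the series" means these few. Any claim that something is new, unique, unknown or untested is made for them only; others in the source may bear on it.

Compound 1 `CCCc1ccc(-c2ccc3ncc(-c4noc(C)n4)cc3c2)cc1` and compound 2 `Cc1nc(-c2cnc3ccc(-c4ccccc4)cc3c2)no1` share a core and differ in one place: hydrogen in place of propyl on an aromatic carbon. In a functional assay on RD cells (Homo sapiens) for inhibition, read by luminescence and ATP content, with a stated time of 72 h (a lower number here means that less compound is tolerated, a higher number that more compound is tolerated), compound 1 gives > 7400 nM, which is a limit of the assay rather than a number. In this assay compound 2 gives > 2500 nM, again a limit and not a number. The step that the two limits leave unreadable from compound 1 to compound 2 therefore cannot be sized; both ends rest on limits, as the limit of > 7400 nM in this assay, at which 1 of the 2 values shown sits, and the limit of > 2500 nM in this assay, at which 1 of the 2 values shown sits, show.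

Compound 3 `CCc1nc(-c2cnc3ccc(-c4ccccc4)cc3c2)no1` differs from compound 2 by methyl in place of hydrogen on a saturated chain carbon bound to an aromatic carbon. Among the measured compounds shown here, no measured step reports such a change, and the one step available is unreadable, so no direction beyond the scatter is expected. Compound 3 is estimated to give 5000 nM, between 1500 nM and 20000 nM, meaning an expected step that the limit leaves unreadable from compound 2 to compound 3, most likely reported again as a limit.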

Compound 3, half-maximal cytotoxic concentration: > 7400 nM
Compound 3: a limit, no number (the forecaster's own chance of this, stated with the estimate: 75%); at least 1.4-fold (0.17 log units) between middle value and limit.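

No new step can be read: in this assay compound 2 and compound 3 both give limits rather than numbers, and the change from methyl to ethyl has no readable size. The compounds shown leave open the cytotoxic concentration of any of them.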